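The source may report more compounds than this note shows. Statements on the series, on what has been measured and on what is new or still open speak of the compounds shown alone.

Series notes. Compound 1 `Cc1ccc(N(C)CC2CCC/C(=C\c3ccc(S(C)(=O)=O)cc3)C2=O)cc1` and compound 2 `Cc1cccc(N(C)CC2CCC/C(=C\c3ccc(S(C)(=O)=O)cc3)C2=O)c1` share one core; compound 3 `COc1ccc(C2(O)/C(=C/c3ccc(C)cc3)CCCC2CN(C)c2ccc(C)cc2)cc1` carries another, and the difference between the two cores is not broken down here. In a functional assay on the whole organism (strain Kunming) for inhibition, with Mus musculus as the target, in the writhing test, with stated times of 1 h and 15 min, at a dose of 200 mg/kg by the oral route (on this read-out higher numbers stand for more inhibition at the one dose given (going by the name of the read-out) and lower numbers for less inhibition), compound 1 gives 84.5%, compound 2 gives 72.8% and compound 3 gives 62.2%, the lowest of the three. The change from compound 1 to compound 2 is 3-methylphenyl in place of 4-methylphenyl on an amine nitrogen, and it made a step of a number 11.7 percentage points lower from compound 1 to compound 2 (beyond the scatter). Compound 4 `COc1ccc(C2(O)/C(=C/c3ccc(C)cc3)CCCC2CN(C)c2cccc(C)c2)cc1` is not yet measured; it differs from compound 3 by 3-methylphenyl in place of 4-methylphenyl on an amine nitrogen, the same change at the same place. Among the compounds with values here, for compound 4 in this assay a step of a number 11.7 percentage points lower from compound 3 to compound 4 (beyond the scatter) is expected, resting on the single measured step of a number 11.7 percentage points lower from compound 1 to compound 2 (beyond the scatter), with the caveat that the cores differ and only one example exists. Compound 4 is expected to give 50.5%, estimated between 38% and 63%.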

Compound 4, a percentage reported as inhibition, in the whole organism at one dose (the size of the read-out at that dose, not a potency): 74.2%
The estimate for compound 4 lay 23.7 percentage points below the measured number; the whole stated range lies below it.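

In this assay, 3-methylphenyl in place of 4-methylphenyl on the amine nitrogen gives a step of a number 12 percentage points higher from compound 3 to compound 4 (beyond the scatter), so the change does not carry over from the core of compound 1 to the core of compound 3 with its direction kept: the same change on two cores in this assay, a number 11.7 percentage points lower (beyond the scatter) from compound 1 to compound 2 and a number 12 percentage points higher (beyond the scatter) from compound 3 to compound 4, 23.7 percentage points apart, beyond the scatter of two such steps. Within the data shown here, in this series, a step measured on one of these cores is therefore no guide to the step on the other. This does not show what sets the two steps apart, and with one pair per core at a single dose, it says nothing about any further core.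

Which of the differences between the two cores goes with the reversal remains open. So does whether an unsubstituted phenyl or a 4-chlorophenyl on the amine nitrogen would also rank differently on the two cores.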